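The source may hold more compounds than are shown below. What is called first, only, known or untested is meant among the compounds shown, and "the series" means these compounds.

Measured compounds:
compound 1 `Cc1ccc(NC(=S)NC(=O)c2cn(-c3ccccc3)nc2-c2ccc(F)cc2)cc1`: 5440 nM
compound 2 `COc1ccc(NC(=S)NC(=O)c2cn(-c3ccccc3)nc2-c2ccc(OC)cc2)cc1`: 4210 nM
compound 3 `Cc1ccc(NC(=S)NC(=O)c2cn(-c3ccccc3)nc2-c2ccccc2)cc1`: 5900 nM

All three were tested in a functional assay on MCF7 cells (Homo sapiens) for inhibition, read by CCK-8 assay, with a stated time of 48 h; on this read-out higher numbers stand for weaker inhibition and lower numbers for stronger inhibition. Compound 2 gives the lowest of the three numbers, but its gaps to compound 1 and to compound 3 both lie within the scatter, so no order among them can be claimed. Within the data shown here, the only single-point step available, a 1.1-fold higher number from compound 1 to compound 3 (0.04 log units; within the scatter), concerns hydrogen in place of fluoro on an aromatic carbon at a different part of the shared core and stays within the scatter. Compound 4 `COc1ccc(-c2nn(-c3ccccc3)cc2C(=O)NC(=S)Nc2ccc(Cl)cc2)cc1` differs from compound 2 by the change (chloro in place of methoxy on an aromatic carbon). Among the measured compounds shown here, no measured step alters a substituent on the ring bearing the amino group, so nothing in the data bears directly on this change; compound 1 and compound 2, which differ at two places at once, give numbers within the scatter of each other. Compound 4 is therefore expected to stay near compound 2, with the step of a 1.1-fold higher number from compound 2 to compound 4 (0.03 log units; within the scatter) expected to fall within the scatter. The estimate for compound 4 is 4500 nM, with a range from 2200 nM to 9000 nM.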

Compound 4, half-maximal inhibitory concentration: 4760 nM
Compound 4: middle estimate off by 1.1-fold (0.02 log units), on the low side; low and high end bracket the measured number.
By their numbers in this assay, from the lowest: compounds 2, 4, 1 and 3 (each within the scatter of the next).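

In this assay, among these compounds, the step of a 1.1-fold higher number from compound 2 to compound 4 (0.05 log units; within the scatter) is the first measured change on the ring bearing the amino group, since the only earlier step lay at a different part of the shared core. At this place, para to a large group, the half-maximal inhibitory concentration does not tell chloro from methoxy, so the 4-methoxyphenyl and 4-chlorophenyl forms of the amino group cannot be separated on this read-out. Nothing among the data shown offers a reason for this result.

As far as these compounds go, whether an amine, a carboxylic acid or a longer chain at this place would give a step beyond the scatter remains open. From the compounds shown here alone, it is also open whether chloro in place of the methoxy that compound 4 keeps, at the other end of the shared core, would read the same way.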